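Difluoroethyl replacement on the aryl side chain

A few compounds are considered here, and "the series" means these few. Any claim that something is new, unique, unknown or untested is made for them only; others in the source may bear on it.

Measured so far:
compound 1 `O=C(CCCN1CCC(C(O)(c2ccccc2)c2ccccc2)CC1)c1ccc(CCO)cc1`, 1300 nM
compound 2 `CC(=O)OCCCc1ccc(C(=O)CCCN2CCC(C(O)(c3ccccc3)c3ccccc3)CC2)cc1`, 2500 nM

Both compounds share the same core and differ only in the chain on the aromatic ring. In an in vitro assay on Sf9 cells for inhibition of cytochrome P450 2J2 (Homo sapiens) (a higher number here means a weaker inhibitor, a lower number a stronger inhibitor), compound 1 gives 1300 nM and compound 2 gives 2500 nM. Among the compounds with values here, the one step known, a 1.9-fold higher number from compound 1 to compound 2 (0.28 log units; within the scatter), is within the scatter, so the two values read as equal. Compound 2 therefore stands at the higher of the two numbers, but not apart from compound 1.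

Compound 3 `O=C(CCCN1CCC(C(O)(c2ccccc2)c2ccccc2)CC1)c1ccc(CC(F)F)cc1` is not yet measured in this assay. The change from compound 2 is difluoromethyl in place of 2-acetoxyethyl on a saturated chain carbon bound to an aromatic carbon. Within the data shown here, the only step on record, from compound 1 to compound 2, swaps one oxygen-bearing chain end for another and says nothing direct about a fluorinated chain; its size, within the scatter, gives no reason to expect a large move. The step from compound 2 to compound 3 is estimated as a 1.6-fold lower number from compound 2 to compound 3 (0.19 log units; within the scatter), that is, no change beyond the scatter. Compound 3 is thus expected to give about 1600 nM in this assay, within the range 500 nM to 5000 nM.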

Compound 3, half-maximal inhibitory concentration: 2200 nM
Beside the measured number, compound 3's estimate is 1.4-fold (0.14 log units) below it; the measured number falls inside the stated range.
By their numbers in this assay, from the lowest: compounds 1, 3 and 2 (each within the scatter of the next).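

In this assay, the chain end on the aromatic ring tolerates a swap to a fluorinated group: difluoromethyl in place of 2-acetoxyethyl gives a 1.1-fold lower number from compound 2 to compound 3 (0.06 log units; within the scatter), and difluoromethyl in place of hydroxymethyl gives a 1.7-fold higher number from compound 1 to compound 3 (0.23 log units; within the scatter). The earlier step compared only two oxygen-bearing chain ends, whereas these steps show that the three compounds stay within the scatter of each other even with no oxygen at this place, with difluoromethyl counting 3 heavy atoms and 0 hydrogen-bond acceptors against 6 heavy atoms and 2 hydrogen-bond acceptors for 2-acetoxyethyl. No other data bearing on this result are available.

As far as these compounds go, since every step at this place lies within the scatter, it remains open whether any change here can move the number beyond the scatter, for example a carboxylic acid or an amine at the chain end. A plain ethyl chain would also be needed to separate the contribution of the two fluorine atoms from that of the chain carrying them, and that question stays open in the compounds shown.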